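The source may hold more compounds than are shown below. What is called first, only, known or untested is meant among the compounds shown, and "the series" means these compounds.

In a functional assay on HCT-116 cells (Homo sapiens) for inhibition, read by sulforhodamine B assay, with a stated time of 48 h (on this read-out higher numbers stand for weaker inhibition of growth and lower numbers for stronger inhibition of growth), compound 1, with the structure `Nc1cc(N)c2nc(-c3ccccc3)c(NCc3ccc(Cl)c(Cl)c3)nc2c1`, gives 24000 nM. Within the data shown here, this is the only plain number available, so compound 1 stands on its own, with nothing measured beside it to rank it against. Compound 2, with the structure `CCOC(=O)[C@H](CCC(=O)O)NC(=O)c1ccc(Sc2nc3cc(N)cc(N)c3nc2-c2ccccc2)cc1`, shows in this assay only a limit of < 100000 nM, which is the limit of < 100000 nM in this assay, at which 1 of the 2 values shown sits, and not a measured number.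

Compound 3, with the structure `COc1ccc(CNc2nc3cc(N)cc(N)c3nc2-c2ccccc2)cc1`, has not yet been measured in this assay. It differs from compound 1 in one place: 4-methoxyphenyl in place of 3,4-dichlorophenyl on a saturated chain carbon bound to a nitrogen on an aromatic ring. Among the measured compounds shown here, no pair of measured compounds differing in a single place is available to show how large a swap of this kind tends to be, so the size of the step can only be guessed from the general experience that a change on a side group of this kind usually moves the value modestly.

On that basis compound 3 is expected to land at about 40000 nM, within 12000 nM to 100000 nM, a step estimated at a 1.7-fold higher number from compound 1 to compound 3 (0.22 log units; within the scatter) from compound 1, which may or may not exceed the usual scatter.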

Compound 3, concentration for total growth inhibition: 27500 nM
Beside the measured number, compound 3's estimate is 1.5-fold (0.16 log units) above it; the range from low to high includes it.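

Among these compounds, compounds 1 and 3 are the first pair here that differ in one place, which makes it possible to read the size of a single swap. In this assay, 4-methoxyphenyl in place of 3,4-dichlorophenyl, on a saturated chain carbon bound to a nitrogen on an aromatic ring, gives a 1.1-fold higher number from compound 1 to compound 3 (0.06 log units; within the scatter), so the two compounds cannot be told apart on this read-out, even though the chlorine atoms of one group give way to the oxygen-bearing methoxy of the other. Nothing at hand explains why this swap leaves the two compounds indistinguishable.

Among the compounds shown here, this single pair compares only two substituted phenyl groups, so it leaves open whether the read-out at this place would stay the same for a group of a different kind. For the compounds shown here, an amine or a carboxylic acid in place of the 4-methoxyphenyl, or a longer chain leading to the same ring, would test that, and the answer could differ from the one this pair gives.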